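Aryl sulfone anilines: fluoro to chloro at the aniline

The source may hold more compounds than are shown below. What is called first, only, known or untested is meant among the compounds shown, and "the series" means these compounds.

Measured compounds:
compound 1 `COc1ccc(Nc2nc3ccccc3nc2S(=O)(=O)c2ccc(C)cc2)cc1` — > 50000 nM
compound 2 `Cc1ccc(S(=O)(=O)c2nc3ccccc3nc2Nc2cccc(O)c2)cc1` — 1690 nM
compound 3 `Cc1ccc(S(=O)(=O)c2nc3ccccc3nc2Nc2ccc(F)cc2)cc1` — 13100 nM

All three share one core and differ only in the aryl group on the nitrogen. In a functional assay on PC-3 cells (Homo sapiens) for cytotoxicity, read by MTT assay, with a stated time of 72 h (on this read-out lower numbers stand for stronger inhibition and higher numbers for weaker inhibition), compound 1 gives > 50000 nM, which is a limit of the assay and not a number (the limit of > 50000 nM in this assay, at which 1 of the 3 values shown sits). In this assay compound 2 gives 1690 nM. Compound 3 gives 13100 nM and so stands as the highest of the two numbers; its nearest neighbour is compound 2, with a 7.8-fold higher number from compound 2 to compound 3 (0.89 log units; beyond the scatter). The step from the limit of compound 1 reads an at least 3.8-fold lower number from compound 1 to compound 3 (0.58 log units; beyond the scatter), and the exchange of the whole aryl group reads an at least 29-fold lower number from compound 1 to compound 2 (1.47 log units; beyond the scatter).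

Compound 4 `Cc1ccc(S(=O)(=O)c2nc3ccccc3nc2Nc2ccc(Cl)cc2)cc1` is the unmeasured member. It differs from compound 3 by chloro in place of fluoro on an aromatic carbon. For the measured compounds named here, no measured step repeats this change. Going by the values given here, the only step that touches the same ring position, an at least 3.8-fold lower number from compound 1 to compound 3 (0.58 log units; beyond the scatter), swapped a larger group for fluoro; it sets the scale of what a single substituent change has done here, but gives no direction for chloro against fluoro. The step is therefore expected to be small, a 1.3-fold lower number from compound 3 to compound 4 (0.12 log units; within the scatter), not beyond the scatter in either direction. For compound 4 in this assay the estimate is 10000 nM, within 3500 nM to 30000 nM.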

Compound 4, half-maximal inhibitory concentration: 9660 nM
Compound 4: middle estimate off by 1.0-fold (0.02 log units), on the high side; measured number inside the range.
By their numbers in this assay, from the lowest: compound 2; then compounds 4 and 3 (each within the scatter of the next). At a limit, above all of these: compound 1.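

In this assay, for the compounds shown here, the exchange on the aromatic carbon para to a large group gives a 1.4-fold lower number from compound 3 to compound 4 (0.13 log units; within the scatter), so chloro and fluoro cannot be told apart at this position, and the first direct reading of this change shows no separation between the two halogens. The distance to the 3-hydroxyphenyl group persists with the new halogen, at a 5.7-fold higher number from compound 2 to compound 4 (0.76 log units; beyond the scatter), so the gap seen earlier with 4-fluorophenyl does not belong to fluoro alone and now holds for both compound 3 and compound 4. The step of an at least 5.1-fold lower number from compound 1 to compound 4 (0.71 log units; beyond the scatter) can be read only as a bound, since compound 1 stands at a limit of the assay and not at a number: the limit of > 50000 nM in this assay, at which 1 of the 4 values shown sits.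

Still open, from the compounds shown here alone, is whether the hydroxyl itself or its place on the ring carries the step to compound 2, since that group differs from the halogen-bearing rings in both respects. Also open, going by these compounds, is how an amine or a carboxylic acid in place of the halogen would read, as the two halogens alone say little about what this position accepts.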